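A few compounds are considered here, and "the series" means these few. Any claim that something is new, unique, unknown or untested is made for them only; others in the source may bear on it.

Compound 1 `ClCC#CCSc1cnc2ccccc2c1Cl`: 13.4 ug/mL
Compound 2 `OCC#CCSc1cnc2ccccc2c1[Se]CC#CCCl`: 2 ug/mL

Of the compounds shown here, two have so far been measured in a functional assay on P388 cells (Mus musculus) for antiproliferative activity, with a stated time of 72 h; on this read-out lower numbers stand for stronger inhibition and higher numbers for weaker inhibition. Compound 1 gives 13.4 ug/mL in this assay. Compound 2 gives 2 ug/mL in this assay, the lowest of the two numbers; the gap to compound 1 lies beyond the usual scatter.

Compound 3 `OCC#CCSc1cnc2ccccc2c1Cl` has not yet been measured. It differs from compound 2 in one place: one chlorine atom in place of a group of 6 heavy atoms (4 carbon, 1 chlorine, 1 selenium; no ring), on an aromatic carbon. Among the measured compounds shown here, no step between measured compounds that differ in only one place is available, so the size of this change can only be estimated. Because compound 1, which also carries a chloro at this position, gives 13.4 ug/mL, the number for compound 3 is expected to move toward that of compound 1, the expected step being a 4.0-fold higher number from compound 2 to compound 3 (0.60 log units; beyond the scatter), beyond the scatter. Compound 3 is therefore estimated at 8 ug/mL, with a range from 3 ug/mL to 20 ug/mL.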

Compound 3, concentration for 50% inhibition: 2.4 ug/mL
Compound 3: the middle estimate sits 3.3-fold (0.52 log units) above what was measured; the measured number lies below the stated range.
By their numbers in this assay, from the lowest: compounds 2 and 3 (each within the scatter of the next); then compound 1.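

In this assay, chloro in place of the group of 6 heavy atoms on this aromatic carbon gives a 1.2-fold higher number from compound 2 to compound 3 (0.08 log units; within the scatter), so the two groups cannot be told apart at this position, and the larger group, with its selenium and triple bond, is not required for a number in this range. Among the compounds shown here, the step that does register lies on the chain instead: hydroxy in place of chloro on the saturated chain carbon bound to a triple-bonded carbon gives a 5.6-fold lower number from compound 1 to compound 3 (0.75 log units; beyond the scatter), the only one of the two steps beyond the scatter. Nothing available explains either step.

Going by these compounds, whether an amine or a carboxylic acid in place of that hydroxy would hold the number of compound 3 remains open. So does the effect of a methoxy group or a longer alkyl chain on the aromatic carbon.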